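Cytotoxicity notes: replacing the oxadiazole on the aryl ring

The compounds below may be only part of what the source reports. "The series", "measured", "known", "first", "only" and "open" are said of these compounds alone.

Measured in an ADME assay on RD cells (Homo sapiens) for cytotoxicity, read by MTT assay, with a stated time of 24 h; on this read-out lower numbers stand for higher toxicity in this test and higher numbers for lower toxicity in this test:
compound 1 `Cc1nc(-c2ccc(OCCC(C)CCN3CCN(c4ccnc(N)c4)C3=O)cc2)no1` gives 66100 nM
compound 2 `CCc1nc(-c2ccc(OCCC(C)CCN3CCN(c4ccnc(N)c4)C3=O)cc2)no1` gives > 100000 nM, a limit of the assay

Compound 2 stands at the limit of this assay, so only a bound is known for it (the limit of > 100000 nM in this assay, at which 1 of the 2 values shown sits). Within the data shown here, the one measured step, an at least 1.5-fold higher number from compound 1 to compound 2 (0.17 log units; that floor lies within the scatter), lies within the scatter. Compound 3 `CCONCc1ccc(OCCC(C)CCN2CCN(c3ccnc(N)c3)C2=O)cc1` differs from compound 2 by (ethoxyamino)methyl in place of 5-ethyl-1,2,4-oxadiazol-3-yl on an aromatic carbon. Among the measured compounds shown here, no measured step covers this change; the single step known gives no direction beyond the scatter. The step of an at least 1.1-fold lower number from compound 2 to compound 3 (0.04 log units; that floor lies within the scatter) is estimated to stay within the scatter. Compound 3 is therefore expected near 90000 nM, from 35000 nM to 250000 nM, with a fair chance of again returning only a limit in this assay.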

Compound 3, half-maximal cytotoxic concentration: 7370 nM
Compound 3: middle estimate off by 12-fold (1.09 log units), on the high side; the measured number lies below the stated range.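

In this assay, (ethoxyamino)methyl in place of 5-ethyl-1,2,4-oxadiazol-3-yl gives an at least 13-fold lower number from compound 2 to compound 3 (1.13 log units; beyond the scatter), and in place of 5-methyl-1,2,4-oxadiazol-3-yl it gives a 9.0-fold lower number from compound 1 to compound 3 (0.95 log units; beyond the scatter). This aromatic carbon, para to a large group, therefore moves the read-out toward higher toxicity in this test once the oxadiazole leaves, which the ethyl-for-methyl step within the oxadiazoles did not show. The step from compound 2 is only a floor, and compound 2 is a limit of the assay: the limit of > 100000 nM in this assay, at which 1 of the 3 values shown sits.

As far as these compounds go, whether the shift follows loss of the ring or arrival of the ethoxyamino chain stays open. A plain aminomethyl group or an isoxazole at this carbon would separate the two.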